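The source may report more compounds than this note shows. Statements on the series, on what has been measured and on what is new or still open speak of the compounds shown alone.

Compound 1 `CCc1cc(C(C)=O)c(O)cc1OCCCCCC[S+](C)[O-]` and compound 2 `CCc1cc(C(C)=O)c(O)cc1OCCCCc1nnn[nH]1` share one core and differ only in the group on a saturated chain carbon, four bonds along the chain from an oxygen on an aromatic ring. In an assay on isolated protein for inhibition of leukotriene B4 receptor 1 (Homo sapiens), tested at 10 uM (on this read-out lower numbers stand for less inhibition and higher numbers for more inhibition at the one concentration tested (going by the name of the read-out)), compound 1 gives 92%, and compound 2 gives 49%, the lowest of the two numbers; the step is a number 43 percentage points lower from compound 1 to compound 2 (beyond the scatter). Compound 3 `CCc1cc(C(C)=O)c(O)cc1OCCCCCCc1nnn[nH]1` is not yet measured and differs from compound 2 by 2-(1H-tetrazol-5-yl)ethyl in place of 1H-tetrazol-5-yl on a saturated chain carbon, four bonds along the chain from an oxygen on an aromatic ring. Among the compounds with values here, no measured step keeps the 1H-tetrazol-5-yl ring and changes only the chain, so the large step from compound 1 to compound 2 bears on this only loosely. A modest rise is expected, a number 16 percentage points higher from compound 2 to compound 3 (beyond the scatter). Compound 3 is therefore estimated at 65%, within a range from 40% to 90%.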

Compound 3, a percentage reported as inhibition, at one concentration (the size of the read-out at that concentration, not a potency): 91%
Compound 3: middle estimate off by 26 percentage points, on the low side, and the stated range ends below it.
By their numbers in this assay, from the lowest: compound 2; then compounds 3 and 1 (each within the scatter of the next).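

With the 1H-tetrazol-5-yl ring kept, the length of the chain alone matters at this position: in this assay, 2-(1H-tetrazol-5-yl)ethyl in place of 1H-tetrazol-5-yl gives a number 42 percentage points higher from compound 2 to compound 3 (beyond the scatter) on this change alone. On the longer chain, the end group of compound 1 and the tetrazole ring cannot be told apart, with a number 1 percentage points lower from compound 1 to compound 3 (within the scatter) between them. Nothing measured here gives a reason for either step.

Still open, from the compounds shown here alone, is whether a longer chain keeps this level of inhibition. Also open, going by these compounds, is whether a carboxylic acid in place of the tetrazole ring would match it.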